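Phenyl in place of methyl on the shared core

The source may report more compounds than this note shows. Statements on the series, on what has been measured and on what is new or still open speak of the compounds shown alone.

Compound 2 `COc1cc(/C=C/C(C)=O)ccc1OCc1cn(-c2ccc(C)cc2)nn1` was tested in a functional assay on MCF7 cells (Homo sapiens) for antiproliferative activity, read by MTT assay, with a stated time of 48 h; a higher number here means a weaker inhibitor, a lower number a stronger inhibitor. In this assay compound 2 gives only > 100000 nM, which is a limit of the assay and not a number. Compound 1 `COc1cc(/C=C/C(C)=O)ccc1OCc1cn(-c2ccc([N+](=O)[O-])cc2)nn1`, with a nitro where compound 2 carries a methyl, also sits at a limit: in this assay compound 1 gives > 100000 nM. The step that the two limits leave unreadable from compound 1 to compound 2 cannot be read because both values rest at the limit of > 100000 nM in this assay, at which 2 of the 2 values shown sit. Compound 3 `COc1cc(/C=C/C(C)=O)ccc1OCc1cn(-c2ccc(-c3ccccc3)cc2)nn1` differs from compound 2 by phenyl in place of methyl on an aromatic carbon. Among the compounds with values here, no measured step shows what this change does, so the only guide is that compound 2 itself is already too weak to be measured. Compound 3 is therefore expected to remain weak, with an estimated value near 120000 nM, ranging from 30000 nM to 500000 nM. This estimate means an expected step that the limit leaves unreadable from compound 2 to compound 3, within the scatter.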

Compound 3, half-maximal inhibitory concentration: 65400 nM
For compound 3 the middle estimate is 1.8-fold (0.26 log units) above the measured one, and the stated range covers the measured number.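

Within the data shown here, compound 3 is the only one of the three compounds with a number rather than a limit in this assay, so this position, para to a large group, can carry a group that brings the value into the readable range. Phenyl in place of methyl gives an at least 1.5-fold lower number from compound 2 to compound 3 (0.18 log units; that floor lies within the scatter), and phenyl in place of nitro gives an at least 1.5-fold lower number from compound 1 to compound 3 (0.18 log units; that floor lies within the scatter). Each of these is only a floor, and the step between compound 1 and compound 2 cannot be read, because both compounds rest at a limit: the limit of > 100000 nM in this assay, at which 2 of the 3 values shown sit.

From the compounds shown here alone, it remains open whether the ring itself matters here, or whether a benzyl group, an amine or a carboxylic acid at the same place would give a lower number. The compounds shown also leave open how far the value can fall through changes at this position alone.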